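From 4-fluorophenyl to 4-methoxyphenyl: working notes

The source may hold more compounds than are shown below. What is called first, only, known or untested is meant among the compounds shown, and "the series" means these compounds.

In a functional assay on QG-56 cells (Homo sapiens) for antiproliferative activity (on this read-out lower numbers stand for stronger inhibition and higher numbers for weaker inhibition), compound 1 `Cn1cncc1C(O)(c1ccc(C#N)cc1)c1cc2cc([N+](=O)[O-])cc(-c3ccccc3F)c2o1` reads (89.5 nM), compound 2 `Cn1cncc1C(O)(c1ccc(C#N)cc1)c1cc2cc([N+](=O)[O-])cc(-c3ccc(C#N)cc3)c2o1` reads (32.6 nM) and compound 3 `Cn1cncc1C(O)(c1ccc(C#N)cc1)c1cc2cc([N+](=O)[O-])cc(-c3ccc(F)cc3)c2o1` reads (158 nM). The reading for compound 3 is not separated from that of the 2-fluorophenyl member (a 1.8-fold higher number from compound 1 to compound 3 (0.25 log units; within the scatter)) but is separated from that of the 4-cyanophenyl member (a 4.8-fold higher number from compound 2 to compound 3 (0.69 log units; beyond the scatter)).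

Compound 4 `COc1ccc(-c2cc([N+](=O)[O-])cc3cc(C(O)(c4ccc(C#N)cc4)c4cncn4C)oc23)cc1` carries methoxy in place of fluoro on an aromatic carbon, para to a large group (methoxy in place of fluoro on an aromatic carbon).

For the measured compounds named here, two measured steps bear on this change. The nearest is the exchange of cyano for fluoro at the same place, which is a modest step (a 4.8-fold higher number from compound 2 to compound 3 (0.69 log units; beyond the scatter)). The move to the 4-cyanophenyl group from the 2-fluorophenyl group is also modest (a 2.7-fold lower number from compound 1 to compound 2 (0.44 log units; beyond the scatter)). Neither step involves methoxy, so the data give no direction for this group. The steps do show that changes on this phenyl ring have stayed modest so far, and compound 3 (158 nM) is the natural anchor.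

No shift beyond the scatter is therefore expected, and the expected step is small (a 1.4-fold lower number from compound 3 to compound 4 (0.14 log units; within the scatter)). The estimate for compound 4 is (115 nM), with an expected range from (40 nM) to (300 nM).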

Compound 4, half-maximal inhibitory concentration: 36 nM
Beside the measured number, compound 4's estimate is 3.2-fold (0.50 log units) above it; measured number below the stated range.
By their numbers in this assay, from the lowest: compounds 2 and 4 (each within the scatter of the next); then compounds 1 and 3 (each within the scatter of the next).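

On the aromatic carbon para to a large group, methoxy in place of fluoro gives a clear gain in this assay (a 4.4-fold lower number from compound 3 to compound 4 (0.64 log units; beyond the scatter)), so a change at this position can shift the reading beyond the scatter in a group other than cyano. Methoxy and cyano cannot be separated here (a 1.1-fold higher number from compound 2 to compound 4 (0.04 log units; within the scatter)), and the 4-methoxyphenyl member also stands apart from the 2-fluorophenyl member (a 2.5-fold lower number from compound 1 to compound 4 (0.40 log units; beyond the scatter)), which makes cyano no longer the only group in the series to do so. Nothing available explains why the methoxy and fluoro members differ at this position.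

The compounds shown leave open whether ethoxy, a hydroxyl group, an amine or a carboxylic acid at the same place would read with methoxy and cyano or with fluoro. They also leave open whether the gain from methoxy would persist if another part of the shared core were changed, since every member here keeps the same core and differs only on this one phenyl ring.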